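This account rests on a few compounds, and the source may have more. Where it says the series, first, only, none or still open, it means among the compounds named here.

Measured in a functional assay on HEK293 cells for agonist activity at G-protein coupled receptor 39 (Mus musculus), read by inositol phosphate accumulation; a lower number here means that less compound is needed, a higher number that more compound is needed for the effect:

- compound 1, `CNc1nc(NC2(c3ccc(Cl)cc3)CCC2)cc(-c2ccccn2)n1`, gives 34 nM
- compound 2, `CNc1nc(NCc2ccncc2)cc(-c2ccccn2)n1`, gives 304 nM
- compound 3, `CC(C)(C)CNc1nc(NCC2CC2)cc(-c2ccccn2)n1`, gives 1500 nM

Among these three numbers compound 2 stands second highest: compound 3 gives a higher number and compound 1 a lower one, and both gaps lie beyond the usual scatter. The three compounds share one core and differ only in the group hanging from the amine at the side.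

Compound 4, `CNc1nc(NCc2ccc(Cl)cc2)cc(-c2ccccn2)n1`, has not yet been measured. It differs from compound 2 in one place: 4-chlorophenyl in place of pyridin-4-yl on a saturated chain carbon bound to a nitrogen on an aromatic ring. Nothing is measured for any pair that differs in exactly this way, so the size of the step can only be guessed from the spread of the three numbers. The account expects a step downward in this assay, beyond the scatter, because compound 1 also carrying 4-chlorophenyl gives 34 nM. The expected step is a 3.8-fold lower number from compound 2 to compound 4 (0.58 log units; beyond the scatter). For compound 4 the estimate in this assay is 80 nM, with a range from 25 nM to 250 nM.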

Compound 4, half-maximal effective concentration: 3 nM
Beside the measured number, compound 4's estimate is 27-fold (1.43 log units) above it; measured number outside the range, below it.
By their numbers in this assay, from the lowest: compound 4; then compound 1; then compound 2; then compound 3.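

In this assay, among the compounds shown here, replacing pyridin-4-yl with 4-chlorophenyl on a saturated chain carbon bound to a nitrogen on an aromatic ring gives a 100-fold lower number from compound 2 to compound 4 (2.01 log units; beyond the scatter) and is the first change in this set that can be read in one place. It shows that this position responds sharply to the aromatic group it carries, although this single step combines two differences: the ring nitrogen is gone and a chlorine has entered. Nothing available explains the size of this step.

The compounds shown leave open whether plain phenyl, with neither the ring nitrogen nor the chlorine, would keep most of the step. They also leave open how a fluorine or a methoxy group in place of the chlorine would read at this position.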